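Aryl Change on the Ring Nitrogen: Expected Cytotoxicity

This account rests on a few compounds, and the source may have more. Where it says the series, first, only, none or still open, it means among the compounds named here.

Measured so far:
compound 1 `Oc1cc(C(F)(F)F)ccc1-c1nc(-c2ccccc2O)n(-c2ccc(I)cc2)n1`, 105%
compound 2 `Oc1cc(C(F)(F)F)ccc1-c1nc(-c2ccccc2O)n(-c2ccc(OC(F)(F)F)cc2)n1`, 92.5%

In a functional assay on PC-12 cells (Rattus norvegicus) for cytotoxicity, read by MTT assay, with stated times of 2 h and 24 h, tested at 10 uM (on this read-out higher numbers stand for a stronger effect at the one concentration tested and lower numbers for a weaker effect), compound 1 gives 105%, while compound 2 gives 92.5%. Compound 2 thus stands lowest of the two numbers, separated from compound 1 by the step of a number 12.5 percentage points lower from compound 1 to compound 2 (beyond the scatter). Compound 3 `Oc1cc(C(F)(F)F)ccc1-c1nc(-c2ccccc2O)n(-c2cccc(F)c2)n1` differs from compound 2 in one place: 3-fluorophenyl in place of 4-(trifluoromethoxy)phenyl on an aromatic nitrogen. Among the measured compounds shown here, the one measured step that bears on this position is a number 12.5 percentage points lower from compound 1 to compound 2 (beyond the scatter), a modest shift when one group on the aryl ring was replaced by another. For the measured compounds named here, the present change again replaces the whole aryl group, now with 3-fluorophenyl, so a shift of similar modest size in either direction, or none beyond the scatter, is the reasonable expectation; with no second step at this position, the direction is uncertain. Compound 3 is therefore estimated at 95% in this assay, within 75% to 112%, an expected step of a number 2.5 percentage points higher from compound 2 to compound 3 (within the scatter).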

Compound 3, a percentage reported as activity, at one concentration (the size of the read-out at that concentration, not a potency): 98.3%
The estimate for compound 3 lay 3.3 percentage points below the measured number; the measured number falls inside the stated range.
By their numbers in this assay, from the lowest: compounds 2, 3 and 1 (each within the scatter of the next, the first and the last beyond it).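

In this assay, the move to 3-fluorophenyl is a number 5.8 percentage points higher from compound 2 to compound 3 (within the scatter), and the comparison with the 4-iodophenyl group is a number 6.7 percentage points lower from compound 1 to compound 3 (within the scatter). The aryl group on this aromatic nitrogen can therefore shrink from the 11 heavy atoms of 4-(trifluoromethoxy)phenyl to the 7 of 3-fluorophenyl without a step beyond the scatter, and compound 3 cannot be separated from either earlier compound, although those two differ from each other beyond it. No measurement at hand accounts for these numbers.

Going by these compounds, whether an amine or a carboxylic acid on this aryl ring, or an alkyl chain in place of the whole aryl group, would keep the read-out in the same range remains open. With a single concentration, the compounds also leave potency at this position unresolved.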